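The source may hold more compounds than are shown below. What is called first, only, known or untested is meant among the compounds shown, and "the series" means these compounds.

Measured compounds:
Compound 1, `COCCC[S+]([O-])c1sc2nc(-c3nccs3)cc(-c3cnc(C)n3C)c2c1N`, gives 3.3 nM in an assay for inhibition of 15-hydroxyprostaglandin dehydrogenase [NAD(+)] (Homo sapiens), read by fluorescence, with a stated time of 15 min, in the presence of a further agent that is not named here; on this read-out higher numbers stand for weaker inhibition and lower numbers for stronger inhibition.
Compound 2, `CCCC[S+]([O-])c1sc2nc(-c3nccs3)cc(-c3ccc(COC(=O)CN(C)C)cc3)c2c1N`, gives 3.5 nM in this assay.

The two measured compounds share one core and the same thiazole at one end; they differ in the chain on the sulfur and in the group at the other end of the core. Of the two numbers, compound 2 has the higher one, but its gap to compound 1 lies within the usual scatter of repeated measurements, so the two cannot be told apart on these data.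

Compound 3, `CCCC[S+]([O-])c1sc2nc(-c3nccs3)cc(-c3ccc(CNS(C)(=O)=O)cc3)c2c1N`, has not yet been measured. It differs from compound 2 in one place: methanesulfonamido in place of (((dimethylamino)methyl)carbonyl)oxy on a saturated chain carbon bound to an aromatic carbon. The chain on the sulfur and the rest of the core stay as in compound 2.

Among the compounds with values here, no measured pair shows the effect of this particular change. Both measured compounds sit close together, which suggests the group at this position tolerates variation, so the expected step from compound 2 to compound 3 is a 1.3-fold higher number from compound 2 to compound 3 (0.11 log units; within the scatter), that is, within or near the scatter. The estimate for compound 3 in this assay is 4.5 nM, expected to fall between 1.5 nM and 14 nM.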

Compound 3, half-maximal inhibitory concentration: 4.6 nM
Beside the measured number, compound 3's estimate is 1.0-fold (0.01 log units) below it, and the stated range covers the measured number.
By their numbers in this assay, from the lowest: compounds 1, 2 and 3 (each within the scatter of the next).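

In this assay the exchange of (((dimethylamino)methyl)carbonyl)oxy for methanesulfonamido on a saturated chain carbon bound to an aromatic carbon gives a 1.3-fold higher number from compound 2 to compound 3 (0.12 log units; within the scatter) and so separates the two compounds by no more than repeat measurements would. Within the data shown here, this is the first measured pair that differs only at this place, and it shows that the number holds even though the entering group brings a sulfur and a hydrogen-bond donor while the leaving group has a dimethylamino nitrogen and no donor. Nothing available explains why this exchange makes so little difference.

The compounds shown leave open whether a carboxylic acid, a primary amine or a longer chain carrying the methanesulfonamido group would keep the number in this range. They also leave open whether the same exchange would behave alike with the chain on the sulfur of compound 1.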